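Bromo for isopropyl in a urea series

The compounds below may be only part of what the source reports. "The series", "measured", "known", "first", "only" and "open" are said of these compounds alone.

Measured compounds:
Compound 1, `CC(C)c1ccc(NC(=O)N[C@H](C)c2ccccc2)cc1`, 79%
Compound 2, `CC(C)c1ccc(NC(=O)N[C@@H](C)c2ccccc2)cc1`, 96%
Compound 3, `CC(=O)c1cccc(NC(=O)N[C@@H](C)c2ccccc2)c1`, 95%

All three were tested in an ADME assay on the whole organism with Oryza sativa as the target, tested at 1 uM; a higher number here means a weaker effect of the compound at the concentration tested, a lower number a stronger effect. Compound 2 gives the highest of the three numbers, but compound 3 lies within the usual scatter of it, so the two cannot be told apart. Compound 1 stands further off: the step of a number 17 percentage points higher from compound 1 to compound 2 (beyond the scatter) is explained only by the fact that compounds 1 and 2 differ only in the configuration as drawn.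

The unmeasured compound 4, `C[C@H](NC(=O)Nc1ccc(Br)cc1)c1ccccc1`, differs from compound 2 by bromo in place of isopropyl on an aromatic carbon. No measured step touches this part of the molecule; the only step shown concerns the configuration at the chain carbon, not the aromatic substituent. There is therefore no measured guide to the size or direction of this change, and the plain expectation is a number in the region of compound 2, with no step beyond the scatter.

For compound 4 in this assay the estimated value is 88%, with a range from 72% to 100%. The expected step is a number 8 percentage points lower from compound 2 to compound 4 (within the scatter).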

Compound 4, a percentage reported as activity, at one concentration (the size of the read-out at that concentration, not a potency): 97%
Beside the measured number, compound 4's estimate is 9 percentage points below it; the range from low to high includes it.
By their numbers in this assay, from the lowest: compound 1; then compounds 3, 2 and 4 (each within the scatter of the next).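

In this assay, the first step shown at this aromatic carbon, para to a large group, is a number 1 percentage points higher from compound 2 to compound 4 (within the scatter), with bromo in place of isopropyl. Compounds 2 and 4 cannot be told apart here, so at this configuration of the chain carbon, 3 heavy atoms of carbon can give way to 1 heavy atom of bromine with no step beyond the scatter. Nothing given here explains this result, which remains an observation only.

The compounds shown leave open whether the same exchange would read alike with the opposite configuration at the chain carbon, that of compound 1, which gives the lowest number. They also leave open whether an amine or a carboxylic acid on this aromatic carbon would stand apart from compound 2.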